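The compounds below may be only part of what the source reports. "The series", "measured", "known", "first", "only" and "open" are said of these compounds alone.

Measured compounds:
Compound 1, `O=C(OC[C@H]1CN(c2ccc(-n3cc(-c4ccccn4)cn3)c(F)c2)C(=O)O1)c1ccccc1`. In an ADME assay on HEK293-A cells (Homo sapiens) for cytotoxicity, read by MTT assay, with a stated time of 48 h (on this read-out higher numbers stand for weaker inhibition and lower numbers for stronger inhibition), compound 1 gives > 400 ug/mL, which is a limit of the assay and not a number.
Compound 2, `O=C1O[C@@H](Cn2ccnc2)CN1c1ccc(-n2cc(-c3ccccn3)cn2)c(F)c1`. Compound 2 gives > 400 ug/mL, again a limit of the assay.
Compound 3, `O=C1O[C@@H](CSc2cccs2)CN1c1ccc(-n2cc(-c3ccccn3)cn2)c(F)c1`. Compound 3 gives > 400 ug/mL, also a limit of the assay.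

Compound 3 thus stands at the limit of this assay, with nothing to place it above or below the other two; all three values sit at the limit of > 400 ug/mL in this assay, at which 3 of the 3 values shown sit. The three steps between them, a step that the two limits leave unreadable from compound 1 to compound 2, a step that the two limits leave unreadable from compound 1 to compound 3 and a step that the two limits leave unreadable from compound 2 to compound 3, can therefore not be read in size or direction.

Compound 4, `O=CNC[C@H]1CN(c2ccc(-n3cc(-c4ccccn4)cn3)c(F)c2)C(=O)O1`, differs from compound 3 by formylamino in place of (thiophen-2-yl)sulfanyl on a saturated chain carbon bound to a saturated ring carbon. Going by the values given here, the only measured steps that bear on this change are those just named, each between two values at the limit, so none gives a readable size. Among the compounds with values here, with every change at this position so far leaving the value at the limit, no step beyond the scatter is expected in this assay from compound 3 to compound 4 either, and the most likely outcome is a further limit.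

Compound 4 is therefore estimated at 400 ug/mL, within 250 ug/mL to 800 ug/mL. This estimate amounts to an expected a number no higher from compound 3 to compound 4 (the limit leaves the size open), a step expected to stay within the scatter.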

Compound 4, half-maximal inhibitory concentration: > 400 ug/mL
Compound 4 ended at the assay's limit; the forecaster's own chance of this, stated with the estimate: 80%; the middle value sits exactly at the limit.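

Compound 4 sits at the same limit as compound 1, compound 2 and compound 3, so the steps from each of them to compound 4 cannot be read in size or direction: the limit of > 400 ug/mL in this assay, at which 4 of the 4 values shown sit.

The compounds shown leave open how far each lies past that limit in this assay, and whether any group at this place would give a readable value.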